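The source may report more compounds than this note shows. Statements on the series, on what has been measured and on what is new or still open speak of the compounds shown alone.

Measured compounds:
compound 1 `COc1cc(-c2nc(N(C)C)sc2-c2ccc3ccccc3c2)cc(OC)c1OC` — 2900 nM
compound 2 `COc1cc(-c2nc(N(C)C)sc2-c2ccc(C)cc2)cc(OC)c1OC` — 3960 nM
compound 3 `COc1cc(-c2nc(C)sc2-c2ccc3ccccc3c2)cc(OC)c1OC` — 119 nM

In a functional assay on A549 cells (Homo sapiens) for antiproliferative activity, read by MTT assay, with a stated time of 72 h (on this read-out lower numbers stand for stronger inhibition and higher numbers for weaker inhibition), compound 1 gives 2900 nM and compound 2 gives 3960 nM. The two cores differ as follows: 4-methylphenyl in place of naphthalen-2-yl on an aromatic carbon. That difference brings a 1.4-fold higher number from compound 1 to compound 2 (0.14 log units; within the scatter), so the two numbers are not separated. Compound 3 gives 119 nM; its structure differs from compound 1 thus: methyl in place of dimethylamino on an aromatic carbon. This single change makes a 24-fold lower number from compound 1 to compound 3 (1.39 log units; beyond the scatter), the one clear separation among the three measured compounds.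

Compound 4 `COc1cc(-c2nc(C)sc2-c2ccc(C)cc2)cc(OC)c1OC` is not yet measured. It differs from compound 2 in this way: methyl in place of dimethylamino on an aromatic carbon. This is the same kind of change as that from compound 1 to compound 3, now made on the other pair of compounds in this set. The surroundings of the place are not identical: in compound 1 the ring atom two ring bonds away bears a naphthalen-2-yl group, whereas in compound 2 it bears a 4-methylphenyl group (7 heavy atoms). Since the change from naphthalen-2-yl to 4-methylphenyl gave only a 1.4-fold higher number from compound 1 to compound 2 (0.14 log units; within the scatter), the change at the other ring carbon is expected to carry over in this assay in roughly the same size as a 24-fold lower number from compound 1 to compound 3 (1.39 log units; beyond the scatter), with some allowance for the different neighbouring group. The expected step is therefore a 20-fold lower number from compound 2 to compound 4 (1.30 log units; beyond the scatter). Compound 4 is estimated at 200 nM, with a range from 70 nM to 600 nM.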

Compound 4, half-maximal inhibitory concentration: 1950 nM
Estimate against measurement, compound 4: 9.8-fold (0.99 log units) below, outside the stated range (above it).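

In this assay, methyl in place of dimethylamino on the core bearing the 4-methylphenyl group gives a 2.0-fold lower number from compound 2 to compound 4 (0.31 log units; beyond the scatter), so the number falls on both cores, but the size of the step does not carry over from one core to the other: the same change on two cores in this assay, a 24-fold lower number (1.39 log units; beyond the scatter) from compound 1 to compound 3 and a 2.0-fold lower number (0.31 log units; beyond the scatter) from compound 2 to compound 4, 12-fold (1.08 log units) apart, beyond the scatter of two such steps

The large step therefore cannot be applied as a fixed amount across this series. With dimethylamino present, the two aryl groups are not separated, as shown by a 1.4-fold higher number from compound 1 to compound 2 (0.14 log units; within the scatter), whereas with methyl present compound 3 gives 119 nM and compound 4 gives 1950 nM. The two pairs show that the effect of this change differs between these two cores, but they do not explain that difference or show how the change would behave on any other core.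

On these data alone, it remains open whether the large step is peculiar to naphthalen-2-yl or also appears with other aryl groups, such as unsubstituted phenyl or naphthalen-1-yl. The compounds shown also leave open how other groups in place of methyl and dimethylamino, such as a primary amine, ethyl or a longer chain, would read on each of the two cores.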